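Fluoro in place of chloro in a 2,6-dichlorobenzyl series

The source may report more compounds than this note shows. Statements on the series, on what has been measured and on what is new or still open speak of the compounds shown alone.

Measured so far in an ADME assay on MT4 cells (Homo sapiens) for cytotoxicity, read by MTT assay; a lower number here means that less compound is tolerated, a higher number that more compound is tolerated:
compound 1, `O=C(CSc1nc(Cc2c(Cl)cccc2Cl)cc(=O)[nH]1)c1ccc(F)cc1`, gives > 59000 nM, which is a limit of this assay.
compound 2, `CC(C)c1c(Cc2c(Cl)cccc2Cl)nc(SCC(=O)c2ccc(F)cc2)[nH]c1=O`, gives > 54000 nM, likewise a limit.

Compound 2 therefore stands at the limit of > 54000 nM in this assay, at which 1 of the 2 values shown sits, and no number is known for it. For the measured compounds named here, the only measured step, a step that the two limits leave unreadable from compound 1 to compound 2, has ends at two limits and its size cannot be read, so it says nothing about tolerance. Compound 3, `CC(C)c1c(Cc2c(F)cccc2Cl)nc(SCC(=O)c2ccc(F)cc2)[nH]c1=O`, is not yet measured; it differs from compound 2 by fluoro in place of chloro on an aromatic carbon. Going by the values given here, no measured step bears on this change. Compound 3 is expected to give 60000 nM, between 30000 nM and 150000 nM, meaning an expected step that the limit leaves unreadable from compound 2 to compound 3 that stays within the usual scatter, most likely reported again as a limit.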

Compound 3, half-maximal cytotoxic concentration: > 56000 nM
Compound 3: no number, only a limit; the forecaster's own chance of this, stated with the estimate: 85%; the middle value does not contradict the limit.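

Compound 3 also reads only as a limit in this assay, so the steps from compound 1 to compound 2 and from compound 2 to compound 3 cannot be read. What the compounds shown leave open is the actual concentration at which any of them becomes cytotoxic.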